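The source may report more compounds than this note shows. Statements on the series, on what has been measured and on what is new or still open speak of the compounds shown alone.

Two measured compounds share one core, and a third, compound 3 `CC1(C)CC(=O)C(C(=S)SCCO)=C(Nc2ccc(Br)cc2)C1`, is still to be tested. Compound 1 `CC1(C)CC(=O)C(C(=S)SCCO)=C(Nc2ccc(Cl)cc2Cl)C1` carries a (2-hydroxyethyl)sulfanyl group and a dichloro-substituted aniline. In a functional assay on PBMC cells (Homo sapiens) for inhibition, read by thymidine incorporation, with a stated time of 72 h (on this read-out higher numbers stand for weaker inhibition and lower numbers for stronger inhibition), compound 1 reaches only the limit of the test, > 50 ug/mL. Compound 2 `CCCCSC(=S)C1=C(Nc2ccc(Br)cc2)CC(C)(C)CC1=O` instead bears a butylsulfanyl group and a bromo-substituted aniline. In this assay compound 2 likewise stops at the limit, > 50 ug/mL. For the measured compounds named here, both values known so far sit at the same limit, (the limit of > 50 ug/mL in this assay, at which 2 of the 2 values shown sit), so nothing separates compound 1 from compound 2 on these numbers, and no measured step is available to guide an expectation.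

Compound 3 differs from compound 2 in one place: hydroxy in place of ethyl on a saturated chain carbon, two bonds along the chain from a sulfur. The (2-hydroxyethyl)sulfanyl group that enters is the same group found in compound 1. Since compound 1 gives only the limit > 50 ug/mL with that group, no step beyond the usual scatter is expected from compound 2 to compound 3, and the expected step that the limit leaves unreadable from compound 2 to compound 3 is essentially flat. Compound 3 is therefore expected to give about 60 ug/mL in this assay, within a range of 25 ug/mL to 150 ug/mL, most probably again as a limit rather than a number.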

Compound 3, half-maximal inhibitory concentration: 8.3 ug/mL
The estimate for compound 3 lay 7.2-fold (0.86 log units) above the measured number, outside the stated range (below it).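

In this assay, for the compounds shown here, the earlier compounds could not show whether either the (2-hydroxyethyl)sulfanyl group or the 4-bromophenyl group allows a measurable inhibition, yet the two together in compound 3 give a real number rather than a limit. Putting the (2-hydroxyethyl)sulfanyl group in place of butylsulfanyl gives an at least 6.0-fold lower number from compound 2 to compound 3 (0.77 log units; beyond the scatter), and putting 4-bromophenyl in place of 2,4-dichlorophenyl on the amine nitrogen gives an at least 6.0-fold lower number from compound 1 to compound 3 (0.77 log units; beyond the scatter), so each single change, made in the presence of the other group, separates stronger inhibition from a result at the limit. The full size of both steps stays unknown because compound 1 and compound 2 each rest at a limit and not at a number: the limit of > 50 ug/mL in this assay, at which 2 of the 3 values shown sit.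

The compounds shown leave open whether the hydroxy group itself is needed or whether another end group would serve as well, such as an amine or a carboxylic acid on the same chain, and whether a longer chain carrying the hydroxy group would keep the effect. They also leave open how much depends on the bromine, which a 4-chlorophenyl group on the amine nitrogen could help to settle.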